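Cyclopentyl Ether to Diaryl Ether in a Cytotoxicity Series

The source may hold more compounds than are shown below. What is called first, only, known or untested is meant among the compounds shown, and "the series" means these compounds.

Measured compounds:
compound 1, `Cc1cn(C2CCN(Cc3cccc(OC4CCCC4)c3)CC2)c(=O)[nH]c1=O`, 30300 nM
compound 2, `Cc1cn(C2CCN(Cc3cc(Oc4cccc(Cl)c4)ccn3)CC2)c(=O)[nH]c1=O`, > 64000 nM
compound 3, `Cc1cn(C2CCN(Cc3cncc(Oc4cccc(OC(F)(F)F)c4)c3)CC2)c(=O)[nH]c1=O`, > 64000 nM

Going by the values given here, in an ADME assay on MRC5 cells (Homo sapiens) for cytotoxicity, read by fluorescence and resazurin assay, with a stated time of 3 days (a higher number here means a weaker inhibitor, a lower number a stronger inhibitor), compound 1 gives 30300 nM, the only numerical value in this set. For compound 2 the result is > 64000 nM, which is a limit of the assay rather than a number. For compound 3 the result is likewise a limit, > 64000 nM. Two of the three results therefore sit at the limit of > 64000 nM in this assay, at which 2 of the 3 values shown sit, and compound 1 alone yields a readable value.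

Compound 4, `Cc1cn(C2CCN(Cc3cccc(Oc4cccc(C(F)(F)F)c4)c3)CC2)c(=O)[nH]c1=O`, has not yet been measured in this assay. It differs from compound 1 by 3-(trifluoromethyl)phenyl in place of cyclopentyl on an oxygen on an aromatic ring. The shared core is unchanged, and the result is an aryl ether on the benzyl ring, as in compound 2 and compound 3, both of which gave only a limit.

Among the compounds with values here, no step between measured compounds is available, so the direction of change is expected from the pattern of limits: a step of a 1.8-fold higher number from compound 1 to compound 4 (0.26 log units; within the scatter) toward weaker inhibition is expected. Compound 4 is expected to give about 55000 nM, within a range from 20000 nM to 150000 nM, with a fair chance that the assay reports only a limit.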

Compound 4, half-maximal inhibitory concentration: 12400 nM
Compound 4: the middle estimate sits 4.4-fold (0.65 log units) above what was measured; measured number below the stated range.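

In this assay, 3-(trifluoromethyl)phenyl in place of cyclopentyl on an oxygen on an aromatic ring gives a 2.4-fold lower number from compound 1 to compound 4 (0.39 log units; beyond the scatter), a modest step toward stronger inhibition. Going by these compounds alone, this is the first step that can be read at this position, and it shows that the larger aromatic group can raise cytotoxicity here rather than lower it. Compound 2 and compound 3 each give only a limit of the assay and differ from compound 4 in more than one place, so no steps to them can be read: the limit of > 64000 nM in this assay, at which 2 of the 4 values shown sit.

Going by these compounds, what remains open is whether the step comes from the aromatic ring itself or from the trifluoromethyl group on it. A plain phenyl on the same oxygen would separate those two parts, and a phenyl carrying a nitrile or an amine would show how far the result depends on the trifluoromethyl group.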